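From Methyl to Methoxy on the Linking Chain

The compounds below may be only part of what the source reports. "The series", "measured", "known", "first", "only" and "open" are said of these compounds alone.

Of the compounds shown here, three built on one shared core have been measured in an assay on isolated protein for binding affinity to Adrenergic receptor alpha-1 (Homo sapiens), read by radioligand binding; on this read-out higher numbers stand for weaker inhibition and lower numbers for stronger inhibition. Compound 2 `CC(Cc1ccc(O)cc1)CN1CCC(Cc2ccccc2)CC1` gives 91.5 nM, the lowest of the three numbers. Compound 1 `Oc1ccc(CC(O)CN2CCC(Cc3ccccc3)CC2)cc1` gives 305 nM, and compound 3 `Oc1ccc(CC(O)CN2CCC(O)(Cc3ccc(Br)cc3)CC2)cc1` gives 2440 nM. Compound 4 `COC(Cc1ccc(O)cc1)CN1CCC(Cc2ccccc2)CC1` has not yet been measured; it differs from compound 2 in one place: methoxy in place of methyl on a saturated chain carbon bound to two saturated chain carbons.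

Within the data shown here, only one measured step bears on this change: a 3.3-fold lower number from compound 1 to compound 2 (0.52 log units; beyond the scatter), where a hydroxy on that same chain carbon gave way to methyl. A methoxy keeps an oxygen, as a hydroxy does, but carries no hydrogen-bond donor, so it stands between the two groups already seen, and the small size of that earlier step suggests the return toward the hydroxy compound should be partial at most.

Compound 4 is therefore expected to show only a modest rise in this assay, a 2.0-fold higher number from compound 2 to compound 4 (0.29 log units; within the scatter). The estimate for compound 4 is 180 nM, with a range from 70 nM to 450 nM.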

Compound 4, inhibition constant: 305 nM
For compound 4 the middle estimate is 1.7-fold (0.23 log units) below the measured one; measured number inside the range.
By their numbers in this assay, from the lowest: compound 2; then compounds 1 and 4 (each within the scatter of the next); then compound 3.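

In this assay, methoxy in place of methyl on this saturated chain carbon gives a 3.3-fold higher number from compound 2 to compound 4 (0.52 log units; beyond the scatter), a step of the same size as the one seen earlier with hydroxy, a 3.3-fold lower number from compound 1 to compound 2 (0.52 log units; beyond the scatter), but in the opposite direction. Adding methyl to the oxygen of compound 1 gives no change at the digits printed from compound 1 to compound 4 (within the scatter), so among these compounds, the hydrogen on that oxygen makes no difference that this read-out can detect, while replacing the oxygen with a methyl carbon does. Nothing shown here explains this result.

As far as these compounds go, it remains open whether an amine or a fluorine on this carbon would match the oxygen-bearing compounds or compound 2. A longer ether such as ethoxy, or a bare hydrogen at this place, could also show how far the match between hydroxy and methoxy extends.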